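Sulfonamide oxadiazoles: keratinocyte cytotoxicity, next analogue

The compounds below may be only part of what the source reports. "The series", "measured", "known", "first", "only" and "open" are said of these compounds alone.

Measured so far:
compound 1 `NS(=O)(=O)c1cc(-c2nnc(CN3CCN(c4ccc(F)cc4)CC3)o2)c(Cl)cc1SCc1ccccc1` — 110000 nM
compound 2 `NS(=O)(=O)c1cc(-c2nnc(Cn3cc(-c4ccccc4)nn3)o2)c(Cl)cc1SCc1ccccc1` — 300000 nM

Among the compounds with values here, in an ADME assay on HaCaT cells (Homo sapiens) for cytotoxicity, read by MTT assay, with a stated time of 72 h (on this read-out lower numbers stand for stronger inhibition and higher numbers for weaker inhibition), compound 2 gives 300000 nM, the highest of the two numbers so far; the nearest is compound 1 with 110000 nM, a gap that lies beyond the usual scatter. Both compounds share the same core and differ only in the group carried on the five-membered ring.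

Compound 3 `NS(=O)(=O)c1cc(-c2nnc(/C=C/c3cccc(Cl)c3)o2)c(Cl)cc1SCc1ccccc1` is not yet measured. Against compound 2 the change is 2-(3-chlorophenyl)ethenyl in place of (4-phenyl-1H-1,2,3-triazol-1-yl)methyl on an aromatic carbon. Within the data shown here, no step between measured compounds covers this change, so the expectation rests on the two values alone, which sit close to each other at the weak end of the read-out.

For compound 3 a modest step toward a lower number is expected, a 2.0-fold lower number from compound 2 to compound 3 (0.30 log units; within the scatter), though one that may well stay within the scatter. The estimate for compound 3 in this assay is 150000 nM, with a range from 50000 nM to 400000 nM.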

Compound 3, half-maximal inhibitory concentration: 16000 nM
The estimate for compound 3 lay 9.4-fold (0.97 log units) above the measured number, and the stated range ends above it.
By their numbers in this assay, from the lowest: compound 3; then compound 1; then compound 2.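

In this assay, the aromatic carbon of the five-membered aromatic ring with 2 nitrogen and 1 oxygen proves to be a position where one replacement moves the read-out strongly: 2-(3-chlorophenyl)ethenyl in place of (4-phenyl-1H-1,2,3-triazol-1-yl)methyl gives a 19-fold lower number from compound 2 to compound 3 (1.27 log units; beyond the scatter). This single change removes a five-membered aromatic ring and 3 hydrogen-bond acceptors and brings in chlorine and a double bond outside aromatic rings, so the step cannot be assigned to any one of these features. Nothing available explains the size of this step.

On these data alone, it remains open whether the chlorine or the double bond carries the step, a question that 2-phenylethenyl or a saturated 2-(3-chlorophenyl)ethyl chain at this position would address. As far as these compounds go, the response to an amine or a carboxylic acid on the aromatic ring of the ethenyl group also remains open.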